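Methyl to Methoxy in Two Related Muscarinic Ligands

The source may report more compounds than this note shows. Statements on the series, on what has been measured and on what is new or still open speak of the compounds shown alone.

The measured compounds:
compound 1, `Cc1ccc(CCCOC(=O)N(c2ccccc2)C2CN3CCC2CC3)cc1F`: 130 nM
compound 2, `Cc1ccc(COC(=O)N(c2ccccc2)C2CN3CCC2CC3)cc1F`: 30 nM
compound 3, `COc1ccc(CCCOC(=O)N(c2ccccc2)C2CN3CCC2CC3)cc1F`: 260 nM

Three compounds have been examined in an assay on CHO cells for displacement of a labelled ligand from muscarinic acetylcholine receptor M5 (Homo sapiens), read by scintillation counting, with a stated time of 2 h; on this read-out higher numbers stand for weaker inhibition and lower numbers for stronger inhibition. Compound 2 gives the lowest number of the three, with compound 1 and compound 3 both standing beyond the scatter from it. Compound 1 and compound 3 differ in one place only: methoxy in place of methyl on an aromatic carbon. This change produced a 2.0-fold higher number from compound 1 to compound 3 (0.30 log units; within the scatter), so the two are read as equivalent within the scatter of this assay.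

Compound 2 shares the same pair of rings with compound 1 but the difference between the two cores is not broken down here.

Compound 4, `COc1ccc(COC(=O)N(c2ccccc2)C2CN3CCC2CC3)cc1F`, has not yet been measured. It stands to compound 2 exactly as compound 3 stands to compound 1: methoxy in place of methyl on an aromatic carbon. The surroundings of the change are described in the same words in both pairs, so it is the same change made on a second core.

Because the earlier case showed a 2.0-fold higher number from compound 1 to compound 3 (0.30 log units; within the scatter), the step from compound 2 to compound 4 is expected to be of similar size, an estimated 2.0-fold higher number from compound 2 to compound 4 (0.30 log units; within the scatter). On that basis compound 4 is expected to fall near 60 nM, with a likely range from 25 nM to 150 nM, resting on a single precedent in this assay.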

Compound 4, inhibition constant: 40 nM
Estimate against measurement, compound 4: 1.5-fold (0.18 log units) above, and the stated range covers the measured number.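

In this assay, methoxy in place of methyl on an aromatic carbon, para to a large group and ortho to a fluoro group, gives a 1.3-fold higher number from compound 2 to compound 4 (0.12 log units; within the scatter), so compound 2 and compound 4 read as equivalent. Set beside the earlier pair, the change carries from one core to the other with no difference that this read-out can resolve, and in both pairs its step stays within the usual scatter: the same change on two cores in this assay, a 2.0-fold higher number (0.30 log units; within the scatter) from compound 1 to compound 3 and a 1.3-fold higher number (0.12 log units; within the scatter) from compound 2 to compound 4, 1.5-fold (0.18 log units) apart, within the scatter of two such steps. Within the data shown here, this shows only that the swap from 3-fluoro-4-methylphenyl to 3-fluoro-4-methoxyphenyl was tolerated in these two pairs; it does not show that the swap has no effect at all, that it would behave the same way on a further core, or why the two steps agree.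

The compounds shown leave open whether other groups in the same place, such as ethoxy, an amine or a carboxylic acid, would also stay within the scatter of the methyl compounds, and whether the agreement depends on the fluoro group that all four compounds carry. They also leave open whether the two cores would treat the change alike at other muscarinic receptors, since every value here comes from a single receptor.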